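Notes on the aryl group: compounds 1 to 3

The source may report more compounds than this note shows. Statements on the series, on what has been measured and on what is new or still open speak of the compounds shown alone.

Measured so far:
compound 1 `CC(C)[C@@H]1CC[C@@H](C)C[C@@]12N(C)C(=O)[C@@H]1[C@H]3C(=O)N(c4ccc(Cl)cc4)C(=O)[C@H]3ON12`: 29.7%
compound 2 `COc1ccc(N2C(=O)[C@H]3[C@H](ON4[C@@H]3C(=O)N(C)[C@@]43C[C@H](C)CC[C@H]3C(C)C)C2=O)cc1`: 48.9%

Within the data shown here, in a functional assay, read by spectrophotometry, with a stated time of 2 h, tested at 0.5 mg/mL (on this read-out higher numbers stand for a stronger effect at the one concentration tested and lower numbers for a weaker effect), compound 2 stands highest of the two numbers measured, with compound 1 as its only neighbour. Among the measured compounds shown here, the single step measured so far is a number 19.2 percentage points higher from compound 1 to compound 2 (beyond the scatter), methoxy in place of chloro on an aromatic carbon.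

Compound 3 `Cc1cccc(N2C(=O)[C@H]3[C@H](ON4[C@@H]3C(=O)N(C)[C@@]43C[C@H](C)CC[C@H]3C(C)C)C2=O)c1` differs from compound 2 by 3-methylphenyl in place of 4-methoxyphenyl on an amide-type nitrogen in a ring. For the measured compounds named here, no measured step covers this change directly. Going by the values given here, the only step that bears on it is the one from compound 1 to compound 2, which shows that exchanging the group on this amide-type nitrogen moved the read-out beyond the scatter; the present change removes the methoxy rather than exchanging it for another group of the same kind, so a move back towards the lower end of the measured range is expected, with wide uncertainty. Compound 3 is expected to give 35% in this assay, within 15% to 55%. The expected step is a number 13.9 percentage points lower from compound 2 to compound 3 (beyond the scatter).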

Compound 3, a percentage reported as activity, at one concentration (the size of the read-out at that concentration, not a potency): 16.1%
Estimate against measurement, compound 3: 18.9 percentage points above, within the range that was stated.
By their numbers in this assay, from the lowest: compound 3; then compound 1; then compound 2.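

In this assay, exchange of 4-methoxyphenyl for 3-methylphenyl on the amide-type nitrogen gives a number 32.8 percentage points lower from compound 2 to compound 3 (beyond the scatter) and is a large step, while exchange of 4-chlorophenyl for 3-methylphenyl gives a number 13.6 percentage points lower from compound 1 to compound 3 (beyond the scatter) and is a modest one, so compound 3 is the lowest of the three. The earlier pair showed only a rise at this nitrogen, whereas the read-out can now also be seen to fall under that of compound 1, which therefore does not mark the low end for this position. Nothing at hand accounts for this order of the three aryl groups.

The compounds shown do not separate the change of substituent from the change of its number on the ring, which a 4-methylphenyl or 3-methoxyphenyl group on the same nitrogen would do. Also open, from the compounds shown here alone, is how an amine or a carboxylic acid on this aromatic ring would read.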